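Butyl in place of isopropyl on the shared core

The compounds below may be only part of what the source reports. "The series", "measured", "known", "first", "only" and "open" are said of these compounds alone.

Measured compounds in an assay on isolated protein for inhibition of serine protease 1 (Bos taurus); on this read-out higher numbers stand for weaker inhibition and lower numbers for stronger inhibition:
- compound 1 `CC(=N)N1CCC(Oc2ccc3ncn(Cc4ccc5ccc(C(=N)N)cc5c4)c3c2)CC1`: 50 nM
- compound 2 `CC(=N)N1CCC(Oc2ccc3nc(C(C)C)n(Cc4ccc5ccc(C(=N)N)cc5c4)c3c2)CC1`: 5.7 nM
- compound 3 `CC(=N)N1CCC(Oc2ccc3nc(CCC(N)=O)n(Cc4ccc5ccc(C(=N)N)cc5c4)c3c2)CC1`: 4.4 nM

Compound 2 stands second highest of the three numbers. Its nearest neighbour is compound 3, the gap being a 1.3-fold lower number from compound 2 to compound 3 (0.11 log units; within the scatter), so the two cannot be ordered; its furthest is compound 1, from which the step is an 8.8-fold lower number from compound 1 to compound 2 (0.94 log units; beyond the scatter).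

Compound 4 `CCCCc1nc2ccc(OC3CCN(C(C)=N)CC3)cc2n1Cc1ccc2ccc(C(=N)N)cc2c1` differs from compound 2 in one place: butyl in place of isopropyl on an aromatic carbon. The measured steps that bear on this position are the two from the unsubstituted parent, an 8.8-fold lower number from compound 1 to compound 2 (0.94 log units; beyond the scatter) and an 11-fold lower number from compound 1 to compound 3 (1.06 log units; beyond the scatter), and the exchange of one group for another on the same carbon, a 1.3-fold lower number from compound 2 to compound 3 (0.11 log units; within the scatter). Across the three measured compounds, any group on this aromatic carbon gives a lower number than hydrogen, and the two groups tried, isopropyl and 2-carbamoylethyl, give numbers within the scatter of one another. Butyl in place of isopropyl is a further exchange of one group for another at this position, so no step beyond the scatter is expected; the estimated step is a 1.0-fold lower number from compound 2 to compound 4 (0.02 log units; within the scatter). Compound 4 is therefore expected to give about 5.5 nM in this assay, within a range from 2.2 nM to 14 nM.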

Compound 4, inhibition constant: 5.7 nM
For compound 4 the middle estimate is 1.0-fold (0.02 log units) below the measured one, within the range that was stated.
By their numbers in this assay, from the lowest: compounds 3, 2 and 4 (each within the scatter of the next); then compound 1.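

In this assay, butyl on this aromatic carbon between two ring nitrogen atoms gives a result that cannot be separated from that of isopropyl, with no change at the digits printed from compound 2 to compound 4 (within the scatter), so this exchange leaves the read-out in place. Butyl also cannot be separated from the 2-carbamoylethyl group, with a 1.3-fold higher number from compound 3 to compound 4 (0.11 log units; within the scatter), and it keeps the lower number relative to hydrogen, with an 8.8-fold lower number from compound 1 to compound 4 (0.94 log units; beyond the scatter), so the step away from hydrogen now holds for three different groups and for all the substituted compounds shown, with no compound going against it. These compounds therefore show a flat response among the groups tried, and nothing available accounts for either that flatness or the step from hydrogen.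

The compounds shown leave open how small a group on this carbon can be while keeping the step from hydrogen, with methyl or ethyl as the obvious test cases. They also leave open whether the flat response extends to a chain longer than butyl, a phenyl ring, or a chain ending in an amine or a carboxylic acid.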